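Alkoxy variation on the core of the benzofuran series

A few compounds are considered here, and "the series" means these few. Any claim that something is new, unique, unknown or untested is made for them only; others in the source may bear on it.

Compound 1 `COc1nn2cc(-c3cc4ccccc4o3)nc2s1` is the smaller of the two numbers recorded so far: in a functional assay on HEK293 cells for antagonist activity at proteinase-activated receptor 4 (Homo sapiens), read by FLIPR and calcium flux, with a stated time of 30 min (on this read-out lower numbers stand for stronger inhibition and higher numbers for weaker inhibition), compound 1 gives 4 nM. Its nearest neighbour is compound 2 `COc1nn2cc(-c3cc4c(OC)cccc4o3)nc2s1`, which in this assay gives 7.6 nM; the step of a 1.9-fold higher number from compound 1 to compound 2 (0.28 log units; within the scatter), methoxy in place of hydrogen on an aromatic carbon, lies within the scatter, so the two values cannot be ordered.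

Compound 3 `CC(C)Oc1nn2cc(-c3cc4ccccc4o3)nc2s1` differs from compound 1 elsewhere: isopropyl in place of methyl on an oxygen on an aromatic ring. Going by the values given here, no measured step touches the group on this oxygen; the only step available, from compound 1 to compound 2, changes the aromatic carbon substituent and is not informative for the alkoxy chain. The expectation for compound 3 therefore rests on compound 1 alone, and with nothing to show a shift in either direction, no step beyond the scatter is expected in this assay, the step of a 1.3-fold higher number from compound 1 to compound 3 (0.10 log units; within the scatter) being the estimated outcome. On that basis compound 3 is estimated at 5 nM in this assay, with a range from 1.5 nM to 20 nM reflecting the absence of any directly comparable measurement.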

Compound 3, half-maximal inhibitory concentration: 760 nM
Beside the measured number, compound 3's estimate is 150-fold (2.18 log units) below it; measured number above the stated range.
By their numbers in this assay, from the lowest: compounds 1 and 2 (each within the scatter of the next); then compound 3.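

In this assay, going by these compounds alone, the group on the oxygen on the aromatic ring is the first place in these notes where a change moves the number beyond the scatter: methoxy to isopropoxy, with the shared core left as it is, gives a large step (a 190-fold higher number from compound 1 to compound 3 (2.28 log units; beyond the scatter)). The only earlier step, on an aromatic carbon (a 1.9-fold higher number from compound 1 to compound 2 (0.28 log units; within the scatter)), stays within the scatter, so among the compounds shown this oxygen substituent is the one place where the number responds strongly, and the response is a loss of inhibition. No measurement is at hand that accounts for the size of this step.

An ethoxy group or a straight propoxy chain on the same oxygen would show whether the number rises gradually from methoxy to isopropoxy or only with isopropyl itself, and a cyclopropyl group or an amine-bearing chain there would test how far the loss extends to other groups. Going by these compounds, it also remains open whether isopropoxy produces a step of similar size on compound 2, which carries the added methoxy on the aromatic carbon.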